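The source may report more compounds than this note shows. Statements on the series, on what has been measured and on what is new or still open speak of the compounds shown alone.

Compound 1 `C#CCN(Cc1ccc(OCc2cccc(F)c2)cc1F)[C@@H](C)C(N)=O` — 8710 nM
Compound 2 `C[C@H](NCc1ccc(OCc2cccc(F)c2)cc1C1CC1)C(N)=O` — 75200 nM

In an assay on Sf9 cells for inhibition of Amine oxidase [flavin-containing] A (Homo sapiens), with stated times of 15 min and 60 min (a lower number here means a stronger inhibitor, a higher number a weaker inhibitor), compound 1 gives 8710 nM, the lowest number of the two measured. Compound 2 gives 75200 nM, a far higher number, well beyond the scatter. Compound 3 `C#CCN(Cc1ccc(OCc2cccc(F)c2)cc1Cl)[C@@H](C)C(N)=O` has not been measured yet. It differs from compound 1 in one place: chloro in place of fluoro on an aromatic carbon. Going by the values given here, no measured pair differs by a single change, so there is no direct guide to the size of this step; the expectation is a small change, within the scatter or slightly toward a lower number. Compound 3 is expected to give 6000 nM, in the range 2000 nM to 20000 nM. The step of a 1.5-fold lower number from compound 1 to compound 3 (0.16 log units; within the scatter) is the expected outcome.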

Compound 3, half-maximal inhibitory concentration: 5600 nM
Estimate against measurement, compound 3: 1.1-fold (0.03 log units) above; the measured number falls inside the stated range.
By their numbers in this assay, from the lowest: compounds 3 and 1 (each within the scatter of the next); then compound 2.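

Chloro in place of fluoro gives a 1.6-fold lower number from compound 1 to compound 3 (0.19 log units; within the scatter) in this assay at this aromatic carbon, ortho to a large group. This first single-place comparison shows that the two halogens cannot be told apart here. Nothing available explains this result.

Open, from the compounds shown here alone, is whether a methoxy group, a trifluoromethyl group or plain hydrogen at this carbon would also leave the number unmoved. Compound 2 differs from compound 1 in more than one place, so it cannot settle what a larger group here does.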